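The source may hold more compounds than are shown below. What is called first, only, known or untested is meant among the compounds shown, and "the series" means these compounds.

Compound 1 `c1csc(CNc2ncnc3c2ncn3C2CCCO2)c1`: 107%
Compound 2 `Clc1nc(NCc2ccco2)c2ncn(C3CCCO3)c2n1`: 105%

In an ADME assay on NHDF cells (Homo sapiens) for cytotoxicity, read by neutral red uptake, with a stated time of 24 h, tested at 31.3 uM (a higher number here means a stronger effect of the compound at the concentration tested, a lower number a weaker effect), compound 1 gives 107%. In this assay compound 2 gives 105%, a number within the scatter of compound 1, so neither can be set apart from the other on these two measurements. Compound 3 `Clc1nc(NCC2CCCO2)c2ncn(C3CCCO3)c2n1` is not yet measured; it differs from compound 2 in one place: oxolan-2-yl in place of furan-2-yl on a saturated chain carbon bound to a nitrogen on an aromatic ring. For the measured compounds named here, no measured pair here shows the effect of such a change. The two measured numbers sit close together, and for compound 3 a step in this assay of a number 2 percentage points lower from compound 2 to compound 3 (within the scatter) is expected, no change beyond the scatter. Compound 3 is estimated at 103%, within a range of 90% to 115%.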

Compound 3, a percentage reported as activity, at one concentration (the size of the read-out at that concentration, not a potency): 106%
Compound 3: the middle estimate sits 3 percentage points below what was measured, within the range that was stated.
By their numbers in this assay, from the lowest: compounds 2, 3 and 1 (each within the scatter of the next).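

In this assay, putting oxolan-2-yl in place of furan-2-yl on a saturated chain carbon bound to a nitrogen on an aromatic ring gives a number 1 percentage points higher from compound 2 to compound 3 (within the scatter). This is the first pair shown that differs in one place, and at this position the read-out does not separate the aromatic ring from the non-aromatic one. No supporting measurement bears on why the two groups read alike.

On these data alone, whether an amine, a carboxylic acid or a longer chain at this place would move the number beyond the scatter remains open.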